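From Bromo to Fluoro on the Aromatic Ring

This account rests on a few compounds, and the source may have more. Where it says the series, first, only, none or still open, it means among the compounds named here.

Of the compounds shown here, two sharing one core have been measured in a functional assay on OVCAR-3 cells (Homo sapiens) for inhibition, read by MTT assay, with a stated time of 24 h; on this read-out higher numbers stand for weaker inhibition and lower numbers for stronger inhibition. Compound 1 `CC1(C)[C@H]2CC[C@]1(C)N(Cc1cn(-c3cccc(Cl)c3)nn1)C(=O)C2` gives 50 nM in this assay, while compound 2 `CC1(C)[C@H]2CC[C@]1(C)N(Cc1cn(-c3cccc(Br)c3)nn1)C(=O)C2` gives 30 nM. Among the compounds with values here, the one step available, a 1.7-fold lower number from compound 1 to compound 2 (0.22 log units; within the scatter), exchanges one halogen for another, and compound 2 holds the lowest of the two numbers, with compound 1 a close neighbour within the scatter. Compound 3 `CC1(C)[C@H]2CC[C@]1(C)N(Cc1cn(-c3cccc(F)c3)nn1)C(=O)C2` continues the halogen exchange: fluoro in place of bromo on an aromatic carbon. Within the data shown here, only the step from compound 1 to compound 2 bears on it, and its size was within the scatter, so no step beyond the scatter is expected in this assay for the change from compound 2 to compound 3, though a somewhat higher number is judged more likely than a lower one. Compound 3 is therefore expected to give 70 nM, between 25 nM and 200 nM, an estimated step of a 2.3-fold higher number from compound 2 to compound 3 (0.37 log units; beyond the scatter).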

Compound 3, half-maximal inhibitory concentration: 430 nM
Compound 3: middle estimate off by 6.1-fold (0.79 log units), on the low side; the measured number lies above the stated range.
By their numbers in this assay, from the lowest: compounds 2 and 1 (each within the scatter of the next); then compound 3.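

In this assay this position does not treat all halogens alike: chloro and bromo stay within the scatter of each other (as a 1.7-fold lower number from compound 1 to compound 2 (0.22 log units; within the scatter) shows), whereas fluoro stands clearly apart from both (a 14-fold higher number from compound 2 to compound 3 (1.16 log units; beyond the scatter) and an 8.6-fold higher number from compound 1 to compound 3 (0.93 log units; beyond the scatter)). Within the data shown here, the earlier pair could not reveal this, as its single exchange produced no step beyond the scatter, and only the third halogen shows that a change on this aromatic carbon can matter. Nothing available here explains why fluoro separates from chloro and bromo.

The compounds shown leave open whether iodo would stay with chloro and bromo, and where a methoxy group, a nitrile or an amine on this carbon would fall. They also leave open whether the gap seen with fluoro appears on any other cell line.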